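Compound 1 and a hexyl on an aromatic carbon

The compounds below may be only part of what the source reports. "The series", "measured", "known", "first", "only" and "open" are said of these compounds alone.

Among the measured compounds shown here, compound 1 (`C[C@H]1C[C@H]1C1=N[C@H](/C=C\CCc2ccccc2)CS1`) stands at 19.6 ug/mL in a functional assay on WiDr cells (Homo sapiens) for cytotoxicity (a higher number here means a weaker inhibitor, a lower number a stronger inhibitor), and holds the lower of the two numbers so far. Compound 3 (`CCCCCCc1ccc(CC/C=C\[C@@H]2CSC([C@@H]3C[C@@H]3C)=N2)cc1`) differs from it by one change (hexyl in place of hydrogen on an aromatic carbon): hexyl in place of hydrogen on an aromatic carbon, para to a large group. For the measured compounds named here, the only measured step bearing on this is heptyl in place of hydrogen on an aromatic carbon in compound 2 (`CCCCCCCc1cccc(CC/C=C\[C@@H]2CSC([C@@H]3C[C@@H]3C)=N2)c1`), which gives 69.3 ug/mL in this assay and amounts to a 3.5-fold higher number from compound 1 to compound 2 (0.55 log units; beyond the scatter) as a modest step. Going by the values given here, that is a single case, and no measured compound carries a chain para to a large group, so the read-across is uncertain. A similar move toward a higher number is expected, with an estimated step of a 2.8-fold higher number from compound 1 to compound 3 (0.45 log units; beyond the scatter) as the working figure. For compound 3 the estimated value is 55 ug/mL within an expected range of 22 ug/mL to 130 ug/mL in this series.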

Compound 3, half-maximal inhibitory concentration: 42.5 ug/mL
The estimate for compound 3 lay 1.3-fold (0.11 log units) above the measured number, and the stated range covers the measured number.
By their numbers in this assay, from the lowest: compound 1; then compounds 3 and 2 (each within the scatter of the next).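

In this assay a hexyl para to a large group also gives a higher number (a 2.2-fold higher number from compound 1 to compound 3 (0.34 log units; beyond the scatter)), so the rise seen with the heptyl (a 3.5-fold higher number from compound 1 to compound 2 (0.55 log units; beyond the scatter)) is no longer a single case. Compound 1, with hydrogen at this place, holds the lowest number of the three, while compound 2 and compound 3 lie within the scatter of each other. Nothing available explains the rise on adding either chain.

Going by these compounds, whether a methyl, or a hexyl ending in an amine or a carboxylic acid, would stay close to compound 1 remains open. Compound 2 and compound 3 differ in more than one place, so the effects of chain length and of place on the ring stay unseparated.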